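This account rests on a few compounds, and the source may have more. Where it says the series, first, only, none or still open, it means among the compounds named here.

Compound 1 `Sc1nnc(-c2ccc3c(c2)OCCO3)n1-c1ccccc1` is the parent of this small set. For the measured compounds named here, in a functional assay on BGC-823 cells (Homo sapiens) for antiproliferative activity, read by MTT assay, with a stated time of 24 h (on this read-out higher numbers stand for weaker inhibition and lower numbers for stronger inhibition), compound 1 gives 47000 nM, the highest of the three numbers measured so far. Two benzyl analogues of compound 1 sit lower: compound 2 `O=[N+]([O-])c1ccccc1CSc1nnc(-c2ccc3c(c2)OCCO3)n1-c1ccccc1` gives 26500 nM, a step of a 1.8-fold lower number from compound 1 to compound 2 (0.25 log units; within the scatter), and compound 3 `Fc1ccccc1CSc1nnc(-c2ccc3c(c2)OCCO3)n1-c1ccccc1` gives 18600 nM, a step of a 2.5-fold lower number from compound 1 to compound 3 (0.40 log units; beyond the scatter). The third measured step is a 1.4-fold lower number from compound 2 to compound 3 (0.15 log units; within the scatter). Compound 4 `Brc1cccc(CSc2nnc(-c3ccc4c(c3)OCCO4)n2-c2ccccc2)c1` has not yet been measured; it differs from compound 1 by 3-bromobenzyl in place of hydrogen on a sulfur. The two measured steps that bear on this change, from compound 1 to compound 2 and from compound 1 to compound 3, both put a benzyl group on the same sulfur and both gave lower numbers, one within the scatter and one modestly beyond it. Compound 4 is therefore expected to show a comparable step, a 2.2-fold lower number from compound 1 to compound 4 (0.35 log units; beyond the scatter), in the direction of a lower number. The estimate for compound 4 is 21000 nM, with a range from 9000 nM to 47000 nM.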

Compound 4, half-maximal inhibitory concentration: 65600 nM
Estimate against measurement, compound 4: 3.1-fold (0.49 log units) below; measured number above the stated range.
By their numbers in this assay, from the lowest: compounds 3, 2, 1 and 4 (each within the scatter of the next, the first and the last beyond it).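

Putting a benzyl group on this sulfur does not by itself lower the number: with 3-bromobenzyl in this assay the result is a 1.4-fold higher number from compound 1 to compound 4 (0.14 log units; within the scatter) and compound 4 cannot be told apart from compound 1. The substituted benzyl groups do separate from one another, with a 3.5-fold higher number from compound 3 to compound 4 (0.55 log units; beyond the scatter) and a 2.5-fold higher number from compound 2 to compound 4 (0.39 log units; beyond the scatter) as modest steps, so the outcome at this sulfur depends on what the benzyl ring carries and not only on the benzyl group being there. Nothing available here accounts for these differences.

Still open, from the compounds shown here alone, is whether the gap to compound 3 follows the halogen or its place on the ring, which a 2-bromobenzyl or 3-fluorobenzyl group on the same sulfur would separate. Also open, going by these compounds, is how the number would respond to a group without an aromatic ring on this sulfur, such as a longer alkyl chain or a carboxylic acid.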